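Replacing the Methoxyethylamine on a Shared Sulfone Core

This account rests on a few compounds, and the source may have more. Where it says the series, first, only, none or still open, it means among the compounds named here.

Compound 3 `COCCNC[C@@H]1CCCc2cc(S(=O)(=O)c3cccc(F)c3)ccc21` gives the lowest number of the three compounds measured in an assay on isolated protein for displacement of a labelled ligand from 5-hydroxytryptamine receptor 6 (Homo sapiens) (a lower number here means a stronger inhibitor, a higher number a weaker inhibitor), at 0.251 nM. Compound 2 `O=C(NC[C@@H]1CCCc2cc(S(=O)(=O)c3cccc(F)c3)ccc21)[C@H]1CCCN1` gives 0.631 nM, and compound 1 `O=S(=O)(c1cccc(F)c1)c1ccc2c(c1)CCC[C@H]2CN1CCCS1(=O)=O` gives 31.6 nM. The earlier steps shown here all alter the same position: a 50-fold lower number from compound 1 to compound 2 (1.70 log units; beyond the scatter), a 130-fold lower number from compound 1 to compound 3 (2.10 log units; beyond the scatter) and a 2.5-fold lower number from compound 2 to compound 3 (0.40 log units; beyond the scatter). Compound 4 `CN(C[C@@H]1CCCc2cc(S(=O)(=O)c3cccc(F)c3)ccc21)C(N)=O` changes that position again: carbamoyl(methyl)amino in place of (2-methoxyethyl)amino on a saturated chain carbon bound to a saturated ring carbon. Every earlier change here moved this assay beyond the scatter, and compound 3 sits at the lowest number, so a higher number for compound 4 is expected, of a size between the steps seen so far. The estimate for compound 4 is 2.5 nM (range 0.4 nM to 15 nM), meaning an expected step of a 10-fold higher number from compound 3 to compound 4 (1.00 log units; beyond the scatter).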

Compound 4, inhibition constant: 39.8 nM
Beside the measured number, compound 4's estimate is 16-fold (1.20 log units) below it; measured number outside the range, above it.
By their numbers in this assay, from the lowest: compound 3; then compound 2; then compounds 1 and 4 (each within the scatter of the next).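

In this assay the change to a group with the same heavy-atom count gives a 160-fold higher number from compound 3 to compound 4 (2.20 log units; beyond the scatter), so heavy-atom count alone does not keep the number low at this position. The step of a 63-fold higher number from compound 2 to compound 4 (1.80 log units; beyond the scatter) is also large, whereas a 1.3-fold higher number from compound 1 to compound 4 (0.10 log units; within the scatter) is within the scatter, so two different groups here give matching numbers. Nothing measured here explains these steps. On these data alone, what remains open is whether a plain methylamino or dimethylamino group, without the carbonyl of compound 4, would return to the low number of compound 3.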